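A few compounds are considered here, and "the series" means these few. Any claim that something is new, unique, unknown or untested is made for them only; others in the source may bear on it.

Measured compounds in a functional assay on DLD-1 cells (Homo sapiens) for antiproliferative activity, read by CellTiter-Glo, with a stated time of 72 h; a lower number here means a stronger inhibitor, a higher number a weaker inhibitor:
- compound 1 `CC1CCN(C2CCN(S(=O)(=O)c3cccc4ccccc34)CC2)CC1`: 0.65 nM
- compound 2 `CC(=O)Nc1ccc(S(=O)(=O)N2CCC(N3CCC(C)CC3)CC2)c2ccccc12`: 1100 nM
- compound 3 `CC1CCN(C2CCN(S(=O)(=O)c3cccc(Cl)c3)CC2)CC1`: reported only as a limit, > 5000 nM

Compound 2 sits at the high end of the two numbers shown in this assay; its nearest neighbour is compound 1, and the step from compound 1 to compound 2 is a 1700-fold higher number from compound 1 to compound 2 (3.23 log units; beyond the scatter), the only measured step in the set. For compound 3 the assay reports a limit rather than a number, and that value is noted as such (the limit of > 5000 nM in this assay, at which 1 of the 3 values shown sits).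

The next compound, compound 4 `CC1CCN(C2CCN(S(=O)(=O)c3ccc(Cl)c4ccccc34)CC2)CC1`, differs from compound 2 in one place: chloro in place of acetamido on an aromatic carbon. The acetamido group is the same group whose entry gave the large step of a 1700-fold higher number from compound 1 to compound 2 (3.23 log units; beyond the scatter); here it leaves again, and a single chlorine takes its place on the same aromatic carbon of the fused ring system. The most direct bearing on the new step is therefore that measured one, read in reverse. Compound 3 carries a chloro group on a ring without the fused system and gives only a limit, so it tells little about chlorine on the core of compound 2.

The expectation for compound 4 is a large fall in the number, a step of about a 220-fold lower number from compound 2 to compound 4 (2.34 log units; beyond the scatter), landing near compound 1 but not necessarily matching it. The estimate for compound 4 in this assay is 5 nM, with a range from 1 nM to 40 nM.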

Compound 4, half-maximal inhibitory concentration: 0.1 nM
Compound 4: the middle estimate sits 50-fold (1.70 log units) above what was measured, and the stated range ends above it.
By their numbers in this assay, from the lowest: compound 4; then compound 1; then compound 2. At a limit, above all of these: compound 3.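

In this assay this aromatic carbon of the shared core now has three measured occupants, and the change from acetamido to chloro gives an 11000-fold lower number from compound 2 to compound 4 (4.04 log units; beyond the scatter), which carries the series past the hydrogen of compound 1 rather than merely back to it. Substitution on this carbon is therefore not a penalty in itself: chloro in place of hydrogen gives a 6.5-fold lower number from compound 1 to compound 4 (0.81 log units; beyond the scatter), so the high number of compound 2 goes with acetamido and not with the presence of a group at this place as such. Nothing in the data shown gives a cause for either step.

Acetamido and chloro differ at once in heavy atoms, double bond and hydrogen-bond donor, so these compounds cannot separate which of those features tracks the change in the number. A methoxy group, a primary amine or a bromine on the same carbon would show whether the low number of compound 4 is particular to chloro or extends to other small groups.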